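Working notes: new aryl group on the amine of compound 3

This account rests on a few compounds, and the source may have more. Where it says the series, first, only, none or still open, it means among the compounds named here.

Going by the values given here, in a functional assay on HeLa cells (Homo sapiens) for inhibition, read by sulforhodamine B assay (on this read-out lower numbers stand for stronger inhibition and higher numbers for weaker inhibition), the series so far holds a single true number. Among the compounds with values here, compound 3 (`O=C1C=C(Nc2cccc(F)c2)C(=O)c2c1nc1n2[C@H]2OC[C@@H](O)[C@H]2OC1`) gives 6440 nM and is the only compound with a measured value. Compound 1 (`O=C1C(Nc2ccccc2)=CC(=O)c2c1nc1n2[C@H]2OC[C@@H](O)[C@H]2OC1`) gives > 8000 nM as a limit and not a number. Compound 2 (`O=C1C=C(N2CCC2)C(=O)c2c1nc1n2[C@H]2OC[C@@H](O)[C@H]2OC1`) gives > 16000 nM as a limit as well.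

Within the data shown here, the one measured step is an at least 2.4-fold lower number from compound 2 to compound 3 (0.39 log units; beyond the scatter) and it puts (3-fluorophenyl)amino in place of azetidin-1-yl on a double-bonded ring carbon. Its size rests on the limit of > 16000 nM in this assay, at which 1 of the 3 values shown sits, and not on a number.

Next is compound 4 (`CCOc1ccccc1NC1=CC(=O)c2nc3n(c2C1=O)[C@H]1OC[C@@H](O)[C@H]1OC3`) with 2-ethoxyphenyl in place of 3-fluorophenyl on an amine nitrogen. This change keeps the aryl amine and swaps only the aryl group, so the measured step does not size it. Among the measured compounds shown here, no measured pair compares two aryl groups on that nitrogen. No step beyond the scatter is therefore expected in this assay and no direction is favoured, with compound 3 at 6440 nM as the only anchor. The estimate means a 1.1-fold higher number from compound 3 to compound 4 (0.04 log units; within the scatter) as the expected step. Compound 4 is expected at 7000 nM with an estimated range from 2500 nM to 20000 nM and a real chance of a limit instead of a number.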

Compound 4, half-maximal inhibitory concentration: 6040 nM
The estimate for compound 4 lay 1.2-fold (0.06 log units) above the measured number; the range from low to high includes it.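

Going by these compounds alone, the swap of 3-fluorophenyl for 2-ethoxyphenyl on the amine nitrogen gives a 1.1-fold lower number from compound 3 to compound 4 (0.03 log units; within the scatter) in this assay and is the first comparison of two aryl groups at this position. The two groups cannot be told apart on this read-out, even though 2-ethoxyphenyl brings more heavy atoms and a hydrogen-bond acceptor that 3-fluorophenyl lacks, and unlike the step from azetidin-1-yl, this comparison rests on two true numbers and not on a limit. Within the data shown here, nothing measured so far bears on why this step is so small.

Left open is whether a pyridin-3-yl ring, a benzyl group or a phenyl ring bearing a carboxylic acid on this nitrogen would move the number beyond the scatter, or whether the aryl amines of the series stay in this range whatever the ring carries. On these data alone, compound 2 gives > 16000 nM as a limit and not a number, so the true size of the difference between azetidin-1-yl and an aryl amine at this position also remains open.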